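Working notes: the step from compound 2 to compound 3

The compounds below may be only part of what the source reports. "The series", "measured", "known", "first", "only" and "open" are said of these compounds alone.

- In a physicochemical assay for metabolic stability, read by HPLC (on this read-out lower numbers stand for a shorter-lived compound and higher numbers for a longer-lived compound), compound 1 `O=c1ccn([C@H]2CC[C@@H](COP(=O)(O)Oc3ccncc3)O2)c(=O)[nH]1` gives 23.6 h
- In this assay compound 2 `Cc1ccc(OP(=O)(O)OC[C@H]2O[C@@H](n3cc(C)c(=O)[nH]c3=O)C[C@@H]2N=[N+]=[N-])cn1` gives 28.9 h

Compound 2 stands level with compound 1 on these numbers, as the two values lie within the usual scatter of each other. Compound 3 `Cc1cn([C@H]2C[C@H](N=[N+]=[N-])[C@@H](COP(=O)(O)Oc3ccccc3)O2)c(=O)[nH]c1=O` has not yet been measured in this assay and carries phenyl in place of 6-methylpyridin-3-yl on an oxygen with nothing else changed. Among the measured compounds shown here, no measured pair isolates this change, so the series offers no direct precedent for its size. For the measured compounds named here, compound 1 at 23.6 h and compound 2 at 28.9 h fall within the scatter although their structures differ in more than one place, and this is the only guide available. On that basis, no step beyond the scatter is expected in this assay and no direction can be firmly assigned. The expected step is a 1.1-fold higher number from compound 2 to compound 3 (0.03 log units; within the scatter) and remains within the scatter. The estimate for compound 3 is 31 h with an expected range from 15 h to 65 h in this read-out.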

Compound 3, half-life: 9.47 h
For compound 3 the middle estimate is 3.3-fold (0.52 log units) above the measured one, outside the stated range (below it).
By their numbers in this assay, from the lowest: compound 3; then compounds 1 and 2 (each within the scatter of the next).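

In this assay, among the compounds shown here, the group on an oxygen whose other neighbours are phosphorus proves able to move the half-life: phenyl in place of 6-methylpyridin-3-yl gives a 3.1-fold lower number from compound 2 to compound 3 (0.48 log units; beyond the scatter) as the first single-place step and the first read beyond the scatter. For this one exchange the direction is now set, with the ring of carbon only on the shorter-lived side, though a single pair does not establish a trend across the series. The exchange removes the ring nitrogen and the methyl together, and nothing on hand separates their shares or explains the step.

Still open, going by these compounds, is which of the two parts carries the step, a question that a pyridine ring without the methyl or a phenyl ring bearing a methyl on the core of compound 2 would address. Also open, on these data alone, are whether the same exchange reads alike on the core of compound 1 and how this oxygen tolerates a group of another kind, such as a longer alkyl chain or an amine.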